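The source may report more compounds than this note shows. Statements on the series, on what has been measured and on what is new or still open speak of the compounds shown alone.

Of the compounds shown here, three have been measured in a functional assay on the whole organism for inhibition, with Mythimna separata as the target, with a stated time of 5 days; a lower number here means that less compound is needed, a higher number that more compound is needed for the effect. Compound 1 `CC(C)(C)n1ncc(OCc2nnc(-c3cc(F)c(Cl)cc3Cl)s2)c(Cl)c1=O` gives 67100 nM. Compound 2 `CC(C)(C)n1ncc(OCc2nnc(-c3c(F)c(F)c(F)c(F)c3F)o2)c(Cl)c1=O` gives 271000 nM. Compound 3 `CCc1ccc(-c2nnc(COc3cnn(C(C)(C)C)c(=O)c3Cl)o2)cc1` gives 14500 nM. Compound 2 therefore stands at the highest number of the three: compound 1 lies at a lower number, and compound 3 lies at a lower number still, and both of those differences are beyond the usual scatter of this assay.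

Compound 4 `CC(C)(C)n1ncc(OCc2nnc(-c3cc(F)c(F)c(F)c3F)o2)c(Cl)c1=O` has not yet been measured. It differs from compound 2 in one place: hydrogen in place of fluoro on an aromatic carbon. One fluoro group on the six-membered aromatic ring of carbon only is thus replaced by a hydrogen atom, and everything else stays as in compound 2.

Among the compounds with values here, no measured pair in this set shows the effect of removing a single fluoro group, so the size of the step from compound 2 to compound 4 rests on the value of compound 2 alone. A small shift toward a lower number is expected, as the step of a 1.6-fold lower number from compound 2 to compound 4 (0.20 log units; within the scatter) expresses, and it may well stay within the scatter. Compound 4 is expected to give about 170000 nM in this assay, with a likely range from 60000 nM to 450000 nM.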

Compound 4, half-maximal effective concentration: 240000 nM
For compound 4 the middle estimate is 1.4-fold (0.15 log units) below the measured one; measured number inside the range.
By their numbers in this assay, from the lowest: compound 3; then compound 1; then compounds 4 and 2 (each within the scatter of the next).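

In this assay, replacing one fluoro group on the aromatic ring with hydrogen gives a 1.1-fold lower number from compound 2 to compound 4 (0.05 log units; within the scatter), a step within the scatter, so compound 2 and compound 4 cannot be told apart. Within the data shown here, this is the first pair in the set that differs in only one place, and it shows that at this position, ortho to a large group, the assay does not distinguish fluoro from hydrogen. No supporting measurement bears on why this is so.

The compounds shown leave open whether a different group at this position, such as a methoxy group or an amine, would move the number beyond the scatter. They also leave open whether replacing any of the remaining fluoro groups with hydrogen would be equally silent.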